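The compounds below may be only part of what the source reports. "The series", "measured", "known", "first", "only" and "open" are said of these compounds alone.

Compound 3 `CC(=O)N1CCN=C(c2cccc(Cl)c2)c2c(C)nn(C)c21` is the weakest point of this small set, and it is known only as a limit: in a functional assay on the whole organism for positive allosteric modulation, with Rattus norvegicus as the target (on this read-out higher numbers stand for an effect only at larger amounts of compound and lower numbers for an effect already at smaller amounts), compound 3 gives > 10 mg/kg, which is a limit of the method rather than a number. Its two neighbours carry a hydrogen or a methyl where compound 3 carries an acetyl. Compound 1 `Cc1nn(C)c2c1C(c1cccc(Cl)c1)=NCCN2` gives 0.63 mg/kg in this assay, and compound 2 `Cc1nn(C)c2c1C(c1cccc(Cl)c1)=NCCN2C` gives 0.63 mg/kg. The step of no change at the digits printed from compound 1 to compound 2 (within the scatter) shows that a small alkyl in that position makes no difference, while the steps of an at least 15-fold higher number from compound 1 to compound 3 (1.20 log units; beyond the scatter) and an at least 15-fold higher number from compound 2 to compound 3 (1.20 log units; beyond the scatter) show that the acetyl is what pushes the compound to the limit (the limit of > 10 mg/kg in this assay, at which 1 of the 3 values shown sits).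

Compound 4 `CCN1CCN=C(c2cccc(Cl)c2)c2c(C)nn(C)c21` replaces the acetyl with a further alkyl: ethyl in place of acetyl on a nitrogen on an aromatic ring in a ring. Because the alkyl-for-hydrogen step no change at the digits printed from compound 1 to compound 2 (within the scatter) stayed within the scatter and the acetyl steps an at least 15-fold higher number from compound 1 to compound 3 (1.20 log units; beyond the scatter) and an at least 15-fold higher number from compound 2 to compound 3 (1.20 log units; beyond the scatter) were large, compound 4 is expected to return to the region of compounds 1 and 2, a move of about an at least 10-fold lower number from compound 3 to compound 4 (1.00 log units; beyond the scatter) in this assay. The estimate for compound 4 is 1 mg/kg, with a range from 0.3 mg/kg to 3 mg/kg.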

Compound 4, minimum effective dose: 0.63 mg/kg
Estimate against measurement, compound 4: 1.6-fold (0.20 log units) above; the range from low to high includes it.
By their numbers in this assay, from the lowest: compounds 1, 2 and 4 (each within the scatter of the next). At a limit, above all of these: compound 3.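

In this assay, the steps of no change at the digits printed from compound 1 to compound 4 (within the scatter) and no change at the digits printed from compound 2 to compound 4 (within the scatter) show that this nitrogen accepts an ethyl as well as a methyl or a hydrogen, so the earlier result for a methyl now reaches one further carbon. Ethyl and acetyl both hold 2 carbon atoms, yet the change gives an at least 15-fold lower number from compound 3 to compound 4 (1.20 log units; beyond the scatter), so the carbon count of the group does not decide the outcome here, and what sets compound 3 apart is the carbonyl oxygen of the acetyl. The value of compound 3 is a limit, not a number: the limit of > 10 mg/kg in this assay, at which 1 of the 4 values shown sits.

From the compounds shown here alone, whether a longer chain such as propyl or butyl, or a chain ending in an amine or a carboxylic acid, would stay level with compounds 1, 2 and 4 remains open. Also open, going by these compounds, is whether a urea or a carbamate on this nitrogen would behave like the acetyl.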